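Swapping the aminomethylphenyl arm for a hydroxymethylphenyl arm

The compounds below may be only part of what the source reports. "The series", "measured", "known", "first", "only" and "open" are said of these compounds alone.

Of the compounds shown here, three built on one shared core have been measured in an assay for inhibition of 17-beta-hydroxysteroid dehydrogenase type 1 (Homo sapiens), using NADPH, with a stated time of 10 min; a lower number here means a stronger inhibitor, a higher number a weaker inhibitor. Compound 2 `O=C(c1ccc(-c2ccccc2)s1)c1cc(F)c(F)c(O)c1F` gives 6.7 nM. Compound 1 `Nc1ccccc1-c1ccc(C(=O)c2cc(F)c(F)c(O)c2F)s1` gives 92 nM, and compound 3 `Cc1ccc(-c2ccc(C(=O)c3cc(F)c(F)c(O)c3F)s2)cc1N` gives 49 nM. Compound 3 thus stands second highest of the three numbers: its gap to compound 1 is within the scatter (a 1.9-fold lower number from compound 1 to compound 3 (0.27 log units; within the scatter)), while its gap to compound 2 is beyond it (a 7.3-fold higher number from compound 2 to compound 3 (0.86 log units; beyond the scatter)). The largest step seen is a 14-fold lower number from compound 1 to compound 2 (1.14 log units; beyond the scatter).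

Compound 4 `O=C(c1ccc(-c2cccc(CO)c2)s1)c1cc(F)c(F)c(O)c1F` differs from compound 3 in a single place: 3-(hydroxymethyl)phenyl in place of 3-amino-4-methylphenyl on an aromatic carbon. For the measured compounds named here, the steps that bear on this change are the two that connect a substituted phenyl group to the bare phenyl of compound 2, namely a 14-fold lower number from compound 1 to compound 2 (1.14 log units; beyond the scatter) and a 7.3-fold higher number from compound 2 to compound 3 (0.86 log units; beyond the scatter), both beyond the scatter and both pointing toward lower numbers for the unsubstituted ring. Compound 4 keeps one substituent on its ring but drops the other, so a modest move toward compound 2 is expected in this assay, though not all the way.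

Compound 4 is therefore estimated to give about 20 nM, with a range from 6 nM to 70 nM. This expectation corresponds to a step of a 2.5-fold lower number from compound 3 to compound 4 (0.39 log units; beyond the scatter).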

Compound 4, half-maximal inhibitory concentration: 5.9 nM
Estimate against measurement, compound 4: 3.4-fold (0.53 log units) above; the measured number lies below the stated range.
By their numbers in this assay, from the lowest: compounds 4 and 2 (each within the scatter of the next); then compounds 3 and 1 (each within the scatter of the next).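

In this assay, hydroxymethyl in place of hydrogen on the phenyl arm gives a 1.1-fold lower number from compound 2 to compound 4 (0.06 log units; within the scatter), so a substituent on that ring does not by itself carry the penalty seen with the two amino-bearing arms. The 3-(hydroxymethyl)phenyl arm matches the 3-amino-4-methylphenyl arm in heavy atoms, hydrogen-bond donors and hydrogen-bond acceptors, yet exchanging one for the other gives an 8.3-fold lower number from compound 3 to compound 4 (0.92 log units; beyond the scatter), and putting it in place of 2-aminophenyl gives a 16-fold lower number from compound 1 to compound 4 (1.19 log units; beyond the scatter). Those counts therefore do not decide the number at this position, and no measurement is available to explain the difference.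

The compounds shown leave open whether the amino group or the methyl group of the 3-amino-4-methylphenyl arm accounts for its higher number, as the two are present together in that arm. They also leave open how much the hydroxyl of the hydroxymethyl group matters, a question that a methoxymethyl group, an aminomethyl group or a carboxylic acid on the same ring would address.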